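The source may hold more compounds than are shown below. What is called first, only, known or untested is meant among the compounds shown, and "the series" means these compounds.

Compound 1 `CS(=O)(=O)c1ccc(Cc2nnc3n2N=C(c2ccc(-c4ccccc4)cc2)CS3)cc1`: 67.9%
Compound 2 `CS(=O)(=O)c1ccc(Cc2nnc3n2N=C(c2cc(Cl)sc2Cl)CS3)cc1`: 25.5%
Compound 3 `CS(=O)(=O)c1ccc(Cc2nnc3n2N=C(c2cc4ccccc4c(=O)o2)CS3)cc1`: 14.9%

Of the compounds shown here, three built on a shared core have been tested in a functional assay on HT-29 cells (Homo sapiens) for cytotoxicity, read by MTT assay, with a stated time of 48 h, tested at 50 uM; a lower number here means a weaker effect, a higher number a stronger effect of the compound at the concentration tested. Compound 1 gives 67.9%. Compound 2 gives 25.5%. Compound 3 gives 14.9%. Compound 2 therefore stands second highest of the three numbers; its nearest neighbour is compound 3, whose value lies lower by a gap beyond the usual scatter, while compound 1 lies furthest away, higher by a gap well beyond the scatter.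

Compound 4 `CS(=O)(=O)c1ccc(Cc2nnc3n2N=C(c2ccc(O)c(C(N)=O)c2)CS3)cc1` has not yet been measured. Relative to compound 2 it carries one change: 3-carbamoyl-4-hydroxyphenyl in place of 2,5-dichlorothiophen-3-yl on a carbon with a double bond to nitrogen. Going by the values given here, no pair of measured compounds differs in a single place, so no measured step guides this change directly. The three measured values do show that the group on this carbon can move the read-out across a wide span. For compound 4 a step of a number 2.5 percentage points higher from compound 2 to compound 4 (within the scatter) is expected in this assay, that is, a modest shift that may well stay within the scatter. Compound 4 is accordingly estimated at 28%, with a range from 12% to 48%.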

Compound 4, a percentage reported as activity, at one concentration (the size of the read-out at that concentration, not a potency): 33.1%
The estimate for compound 4 lay 5.1 percentage points below the measured number, within the range that was stated.
By their numbers in this assay, from the lowest: compound 3; then compounds 2 and 4 (each within the scatter of the next); then compound 1.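

In this assay, putting 3-carbamoyl-4-hydroxyphenyl in place of 2,5-dichlorothiophen-3-yl on this carbon gives a number 7.6 percentage points higher from compound 2 to compound 4 (within the scatter), so the exchange has no effect that can be told from the scatter. Going by these compounds alone, this is the first measured single change at this position, and it shows that the read-out can stay within the scatter even though the group that enters has a six-membered aromatic ring of carbon only, has no chlorine or sulfur, and has hydrogen-bond donors where the group that leaves has none. Nothing known here accounts for this outcome.

On these data alone, compound 4 carries the hydroxy and carbamoyl groups together, so the part each plays at this position remains open. Also open, as far as these compounds go, is how a phenyl ring bearing only one of them, or instead an amine or a carboxylic acid, would read out here.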